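Aryl thioureas on a naphthylethyl core: pyridyl versus thiazolyl

This account rests on a few compounds, and the source may have more. Where it says the series, first, only, none or still open, it means among the compounds named here.

Measured compounds:
compound 1 `C[C@@H](/N=C(\S)Nc1ccc(Cl)cn1)c1cccc2ccccc12` — > 100000 nM; > 100000 nM (2 entries)
compound 2 `C[C@@H](/N=C(\S)Nc1ccccn1)c1cccc2ccccc12` — > 100000 nM
compound 3 `Cc1csc(N/C(S)=N/[C@H](C)c2cccc3ccccc23)n1` — 25900 nM

In a functional assay on RBL-2H3 cells (Rattus norvegicus) for inhibition (on this read-out higher numbers stand for weaker inhibition and lower numbers for stronger inhibition), compound 1 gives > 100000 nM; > 100000 nM (2 entries) in both entries, which is a limit of the assay and not a number. Compound 2 likewise gives > 100000 nM in this assay, again a limit. Within the data shown here, compound 3 is the only compound of the three with a measured number, 25900 nM in this assay; it is therefore the only point of reference. Among the measured compounds shown here, the one measured step is an at least 3.8-fold lower number from compound 2 to compound 3 (0.58 log units; beyond the scatter), with the pyridyl compound at the limit (the limit of > 100000 nM in this assay, at which 1 of the 3 values shown sits).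

Compound 4 `Cc1ccc(N/C(S)=N/[C@H](C)c2cccc3ccccc23)nc1` is not yet measured. It differs from compound 3 by 5-methylpyridin-2-yl in place of 4-methyl-1,3-thiazol-2-yl on an amine nitrogen. For the measured compounds named here, this change runs the earlier step backwards: it returns to a pyridin-2-yl ring, now carrying a methyl, whereas both pyridyl compounds so far, compound 1 and compound 2, sit at the limit. The step of an at least 3.8-fold lower number from compound 2 to compound 3 (0.58 log units; beyond the scatter) therefore suggests that compound 4 falls back toward weaker inhibition, and the expected step is a 3.5-fold higher number from compound 3 to compound 4 (0.54 log units; beyond the scatter). For compound 4 the estimate in this assay is 90000 nM, between 30000 nM and 300000 nM, with a fair chance that only a limit is reported.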

Compound 4, half-maximal inhibitory concentration: 5 nM
Compound 4: middle estimate off by 18000-fold (4.26 log units), on the high side; measured number outside the range, below it.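

Methyl in place of hydrogen on an aromatic carbon of the pyridin-2-yl ring gives an at least 20000-fold lower number from compound 2 to compound 4 (4.30 log units; beyond the scatter) in this assay, and this size is only a floor, set by the limit of the parent compound: the limit of > 100000 nM in this assay, at which 1 of the 4 values shown sits.

The ring preference suggested by an at least 3.8-fold lower number from compound 2 to compound 3 (0.58 log units; beyond the scatter) does not hold once the methyl is present, as 5-methylpyridin-2-yl in place of 4-methyl-1,3-thiazol-2-yl gives a 5200-fold lower number from compound 3 to compound 4 (3.71 log units; beyond the scatter). Compound 1, with a chlorine on its pyridine ring, gives > 100000 nM; > 100000 nM (2 entries), which is a limit, so not every substituent on this ring brings measurable inhibition.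

From the compounds shown here alone, whether an ethyl, a methoxy or a trifluoromethyl group in place of the methyl would keep this level of inhibition stays open. The compounds shown do not tell what lies behind the size of the methyl step.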